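Carboxylate-tailed naphthonitriles: a benzoic acid in place of the chain

A few compounds are considered here, and "the series" means these few. Any claim that something is new, unique, unknown or untested is made for them only; others in the source may bear on it.

Compound 1 `N#Cc1ccc(Nc2cnccc2SCCCCCC(=O)O)c2ccccc12`: 4240 nM
Compound 2 `N#Cc1ccc(Oc2cnccc2SCCCC(=O)O)c2ccccc12`: 1230 nM

In an assay on HEK293 cells for inhibition of solute carrier family 22 member 12 (Homo sapiens), read by scintillation counting, with stated times of 30 min and 15 min (a lower number here means a stronger inhibitor, a higher number a weaker inhibitor), compound 1 gives the higher of the two numbers, with compound 2 the nearer at a gap beyond the scatter. For the measured compounds named here, no step between measured compounds is known.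

Compound 3 `N#Cc1ccc(Nc2cnccc2SCc2ccccc2C(=O)O)c2ccccc12` differs from compound 1 in one place: 2-carboxyphenyl in place of 4-carboxybutyl on a saturated chain carbon bound to a sulfur. Nothing measured here speaks to that exchange, so the step of a 1.7-fold lower number from compound 1 to compound 3 (0.23 log units; within the scatter) is expected to be modest, favouring a lower number but possibly within the scatter. In this assay compound 3 is estimated at 2500 nM, with a range from 800 nM to 8000 nM.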

Compound 3, half-maximal inhibitory concentration: 240 nM
The estimate for compound 3 lay 10-fold (1.02 log units) above the measured number; measured number outside the range, below it.
By their numbers in this assay, from the lowest: compound 3; then compound 2; then compound 1.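

On the saturated chain carbon bound to a sulfur, the group carrying the carboxylic acid matters in this assay: 2-carboxyphenyl in place of 4-carboxybutyl gives an 18-fold lower number from compound 1 to compound 3 (1.25 log units; beyond the scatter) at this place. Both groups end in a carboxylic acid, so the number at this position follows the group that carries the acid and not the presence of the acid alone. No measurement at hand accounts for the size of this step.

Still open, going by these compounds, is how much of the step belongs to the aromatic ring and how much to the acid attached to it. A plain benzyl group or a primary amide in place of the carboxylic acid would separate the two.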